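Phenyl for dichlorophenyl on the sulfonyl of compound 1

The source may hold more compounds than are shown below. What is called first, only, known or untested is meant among the compounds shown, and "the series" means these compounds.

Two members of the series have numbers in a functional assay on MCF7 cells (Homo sapiens) for cytotoxicity, with a stated time of 96 h; a lower number here means a stronger inhibitor of growth, a higher number a weaker inhibitor of growth. Compound 1 `CCOC(=O)c1cc2c(cc1Cl)SC(N(c1ccc(OC)cc1)S(=O)(=O)c1ccc(Cl)cc1Cl)=NS2(=O)=O` gives 2400 nM in this assay. Compound 2 `O=C(Oc1cccc2cccnc12)c1cc2c(cc1Cl)SC(N(c1ccc(F)cc1)S(=O)(=O)c1ccc(Cl)cc1)=NS2(=O)=O` gives 3200 nM in this assay; the two values lie within the scatter of each other, so no order between compound 1 and compound 2 is read from them. Compound 3 `CCOC(=O)c1cc2c(cc1Cl)SC(N(c1ccc(OC)cc1)S(=O)(=O)c1ccccc1)=NS2(=O)=O` has not yet been measured in this assay. It differs from compound 1 in one place: phenyl in place of 2,4-dichlorophenyl on a sulfonyl sulfur. Going by the values given here, no measured pair shows what this difference does, so the expected size of the step rests on the two values alone and on the fact that compound 1 and compound 2 sit close together in this assay. The step from compound 1 to compound 3 is expected to be small, tending toward a somewhat higher number, estimated as a 1.5-fold higher number from compound 1 to compound 3 (0.16 log units; within the scatter). For compound 3 the expected value in this assay is 3500 nM, with a range from 1200 nM to 10000 nM.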

Compound 3, concentration for 50% growth inhibition: 4900 nM
Beside the measured number, compound 3's estimate is 1.4-fold (0.15 log units) below it; low and high end bracket the measured number.
By their numbers in this assay, from the lowest: compounds 1, 2 and 3 (each within the scatter of the next, the first and the last beyond it).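

In this assay the series gains its first step that changes one place only: a 2.0-fold higher number from compound 1 to compound 3 (0.31 log units; beyond the scatter) is modest but beyond the scatter, for phenyl in place of 2,4-dichlorophenyl on a sulfonyl sulfur. The number at this position therefore responds to the aryl group, and the two chlorines are the only atoms that differ, while the activity is not lost without them. No measurement shown here explains the step.

Which chlorine, if either alone, accounts for the step remains open, as does whether it would recur on the other ester and nitrogen aryl combination of compound 2. Also unresolved is how an amino group on the phenyl, or a longer alkyl chain in place of the ring, would read in this assay at this position.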